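A few compounds are considered here, and "the series" means these few. Any claim that something is new, unique, unknown or untested is made for them only; others in the source may bear on it.

Compound 1 `CC1=CC[C@H](C(C)(C)NC(=S)N/N=C/c2ccc(O)cc2)CC1` gives, in a functional assay on MCF7 cells (Homo sapiens) for inhibition, read by sulforhodamine B assay, with a stated time of 48 h (on this read-out lower numbers stand for stronger inhibition of growth and higher numbers for weaker inhibition of growth), a value of > 100000 nM, which is a limit of the assay rather than a number. Compound 2 `CC1=CC[C@H](C(C)(C)NC(=S)N/N=C/c2ccc(N(C)C)cc2)CC1` gives > 100000 nM in this assay, again a limit. Compound 3 `COc1cc(/C=N/NC(=S)NC(C)(C)[C@H]2CC=C(C)CC2)ccc1O` gives 63900 nM in this assay.

Compound 1 therefore stands only at a limit, and it shares that position with one other compound: the limit of > 100000 nM in this assay, at which 2 of the 3 values shown sit. The change to compound 4 `CC1=CC[C@H](C(C)(C)NC(=S)N/N=C/c2cccs2)CC1` is thiophen-2-yl in place of 4-hydroxyphenyl on a carbon with a double bond to nitrogen. The two measured steps touch the same aromatic ring without removing it. Going a step that the two limits leave unreadable from compound 1 to compound 2, the two limits hide the size of the step. Going an at least 1.5-fold lower number from compound 1 to compound 3 (0.19 log units; that floor lies within the scatter), the number falls, though only to a floor that the usual scatter would cover. Neither step gives a reason to expect a clear gain in this assay from compound 4, and a change that removes the ring altogether is not covered by any measured pair. The expectation for compound 4 in this assay is therefore a weak value of about 90000 nM, between 30000 nM and 300000 nM, with a fair chance that only a limit is reported. That estimate means a step of an at least 1.1-fold lower number from compound 1 to compound 4 (0.04 log units; that floor lies within the scatter), expected to stay within the scatter.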

Compound 4, concentration for total growth inhibition: 11500 nM
Estimate against measurement, compound 4: 7.8-fold (0.89 log units) above; the measured number lies below the stated range.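

Exchanging the whole 4-hydroxyphenyl for thiophen-2-yl on the carbon with a double bond to nitrogen gives, in this assay, an at least 8.6-fold lower number from compound 1 to compound 4 (0.93 log units; beyond the scatter). Among the compounds shown here, this is the first step in the set that is printed as beyond the scatter, so the identity of the ring on this carbon counts for more here than the other two changes could show, which left that ring in place. Because compound 1 stands only at a limit, the step has a floor and no exact size, and that limit is shared: the limit of > 100000 nM in this assay, at which 2 of the 4 values shown sit.

This single pair cannot separate the loss of the hydroxy group, the smaller ring and the sulfur atom. A plain phenyl or a furan-2-yl on the same carbon would help to tell these apart.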